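Swapping a fluorophenyl for a pyridyl on a piperazine

This account rests on a few compounds, and the source may have more. Where it says the series, first, only, none or still open, it means among the compounds named here.

Of the compounds shown here, three that share one core have been measured in an assay on isolated protein for inhibition of long-chain fatty acid transport protein 1 (Homo sapiens), read by scintillation counting, with a stated time of 20 min; on this read-out lower numbers stand for stronger inhibition and higher numbers for weaker inhibition. Compound 1 `O=C(CN1CCN(c2cccc(F)c2)CC1)Nc1nc2c(s1)CCCC2` carries a 3-fluorophenyl on the ring nitrogen of its piperazine. In this assay compound 1 gives > 1000 nM, which is a limit of the assay rather than a number. This is the line at which compound 1 sits (the limit of > 1000 nM in this assay, at which 1 of the 3 values shown sits), so where compound 1 stands on the scale shown can only be said to be at or beyond that line. Compound 2 `O=C(CN1CCN(c2ccc(F)cc2)CC1)Nc1nc2ccccc2s1` gives 490 nM in this assay, and compound 3 `O=C(CN1CCN(c2ccc(F)cc2)CC1)Nc1nc2c(s1)CCC2` gives 490 nM; these two values lie within the usual scatter of each other, so no order between them can be read.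

Compound 4 `O=C(CN1CCN(c2cccnc2)CC1)Nc1nc2c(s1)CCCC2` differs from compound 1 in a single place: pyridin-3-yl in place of 3-fluorophenyl on an amine nitrogen in a ring. Going by the values given here, no measured pair describes this change, so the expectation rests on compound 1 alone. With compound 1 known only as a limit, the step from compound 1 to compound 4 is expected to be a step that the limit leaves unreadable from compound 1 to compound 4, that is, no change beyond the scatter in either direction. For compound 4 the estimate in this assay is 1500 nM, with a range from 500 nM to 5000 nM.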

Compound 4, half-maximal inhibitory concentration: > 1000 nM
Compound 4 was reported as a limit; the forecaster's own chance of this, stated with the estimate: 60%; the middle value lies beyond the limit too.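

Compound 1 and compound 4 are both reported as limits in this assay, so no step between them can be read: the limit of > 1000 nM in this assay, at which 2 of the 4 values shown sit.

The compounds shown leave open whether pyridin-3-yl in place of 3-fluorophenyl on an amine nitrogen in a ring changes the inhibition at all on this shared core, and if so, in which direction.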